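The compounds below may be only part of what the source reports. "The series", "measured", "known", "first", "only" and "open" are said of these compounds alone.

Measured so far in a functional assay on MGC-803 cells (Homo sapiens) for antiproliferative activity, read by MTT assay, with a stated time of 48 h; a lower number here means a stronger inhibitor, a higher number a weaker inhibitor:
- compound 1 `COc1ccc(CN(C(=O)CSc2nc3ccccc3s2)c2cc(OC)c(OC)c(OC)c2)cc1[N+](=O)[O-]`: 682 nM
- compound 2 `COc1ccc2nc(SCC(=O)N(Cc3ccc(OC)c(O)c3)c3cc(OC)c(OC)c(OC)c3)sc2c1`: 71 nM
- compound 3 `COc1cc(N(Cc2ccccc2)C(=O)CSc2nc3ccccc3s2)cc(OC)c1OC`: 44300 nM

Of these three, compound 3 has the highest number, which makes it the weakest inhibitor here. Compound 4 `COc1ccc(CN(C(=O)CSc2nc3ccccc3s2)c2cc(OC)c(OC)c(OC)c2)cc1C(F)(F)F` keeps the rest of compound 3 but has 4-methoxy-3-(trifluoromethyl)phenyl in place of phenyl on a saturated chain carbon bound to an amide-type nitrogen.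

Compound 2 differs from compound 3 in more than one place, so it offers no clean comparison. One measured step does bear on the change: a 65-fold higher number from compound 1 to compound 3 (1.81 log units; beyond the scatter). This large step has phenyl replacing 4-methoxy-3-nitrophenyl, so read backwards it points to a lower number for the substituted ring. Among the compounds with values here, compound 4 has trifluoromethyl instead of nitro, and no measurement yet compares those two groups. A large step towards a lower number is therefore expected in this assay, estimated as a 30-fold lower number from compound 3 to compound 4 (1.47 log units; beyond the scatter). For compound 4 the estimated value is 1500 nM, with an expected range of 300 nM to 8000 nM.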

Compound 4, half-maximal inhibitory concentration: 25200 nM
Estimate against measurement, compound 4: 17-fold (1.23 log units) below, outside the stated range (above it).
By their numbers in this assay, from the lowest: compound 2; then compound 1; then compounds 4 and 3 (each within the scatter of the next).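

In this assay the step is a 1.8-fold lower number from compound 3 to compound 4 (0.25 log units; within the scatter), so this larger substituted ring, on a saturated chain carbon bound to an amide-type nitrogen, does not separate from plain phenyl. Exchanging a single group on that ring gives a 37-fold higher number from compound 1 to compound 4 (1.57 log units; beyond the scatter), which shows that a substituted ring alone does not bring the low number of compound 1: with trifluoromethyl in place of nitro, that low number is lost. Nothing available here explains why these two groups differ so widely.

As far as these compounds go, what the 4-methoxy group does on its own remains open, as does whether an amine or a nitrile in place of nitro would sit nearer compound 1 or compound 4. Compound 2 differs from these compounds in more than one place, so it cannot settle either question.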